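Replacing thiophen-3-yl with 4-fluorophenyl in compound 3

This account rests on a few compounds, and the source may have more. Where it says the series, first, only, none or still open, it means among the compounds named here.

Compound 1 `NC(=O)[C@@H]1[C@H](Nc2nc(Nc3ccc(C(=O)N4CCCC4)cc3)ncc2-c2cccnc2)[C@H]2C=C[C@@H]1C2` gives 230 nM
Compound 2 `NC(=O)[C@@H]1[C@H](Nc2nc(Nc3cccc(C(=O)N4CCCC4)c3)ncc2-c2ccoc2)[C@H]2C=C[C@@H]1C2` gives 40 nM
Compound 3 `NC(=O)[C@@H]1[C@H](Nc2nc(Nc3cccc(C(=O)N4CCCC4)c3)ncc2-c2ccsc2)[C@H]2C=C[C@@H]1C2` gives 110 nM

In a functional assay on THP-1 cells (Homo sapiens) for inhibition, read by ELISA, with stated times of 1 h and 18 h (on this read-out higher numbers stand for weaker inhibition and lower numbers for stronger inhibition), compound 3 (110 nM) takes the middle place among the three numbers, with compound 2 lower and compound 1 higher. Among the measured compounds shown here, the single change leading to compound 4 (`NC(=O)[C@@H]1[C@H](Nc2nc(Nc3cccc(C(=O)N4CCCC4)c3)ncc2-c2ccc(F)cc2)[C@H]2C=C[C@@H]1C2`) is this: 4-fluorophenyl in place of thiophen-3-yl on an aromatic carbon.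

For the measured compounds named here, one measured step bears directly on this place, thiophen-3-yl in place of furan-3-yl: a 2.8-fold higher number from compound 2 to compound 3 (0.44 log units; beyond the scatter) (a modest step). Compound 1 also has a six-membered aromatic ring there, and its value (230 nM) is higher, but compound 1 differs from compound 3 elsewhere too, so it offers only a weak hint. Going by the values given here, no measured compound carries 4-fluorophenyl, so the expectation is a small step toward a higher number and weaker inhibition, possibly not beyond the scatter.

In this assay the estimated step is a 1.5-fold higher number from compound 3 to compound 4 (0.16 log units; within the scatter) (a rough expectation). Compound 4 is expected at 160 nM with an estimated range from 55 nM to 450 nM in repeated measurements.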

Compound 4, half-maximal inhibitory concentration: 460 nM
Compound 4: the middle estimate sits 2.9-fold (0.46 log units) below what was measured; measured number outside the range, above it.
By their numbers in this assay, from the lowest: compound 2; then compound 3; then compounds 1 and 4 (each within the scatter of the next).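

In this assay, putting 4-fluorophenyl in place of thiophen-3-yl brings a 4.2-fold higher number from compound 3 to compound 4 (0.62 log units; beyond the scatter) and so weaker inhibition. With the rest of the molecule unchanged, the spread across the three groups at this position reaches a 12-fold higher number from compound 2 to compound 4 (1.06 log units; beyond the scatter) and both five-membered rings give lower numbers than the six-membered ring of carbon only, so the choice of ring here can shift this read-out substantially. No measurement shown explains why the number rises with this change.

Ring size and the fluorine change together in this step, so the compounds shown cannot tell which of the two goes with the higher number. Also open, from the compounds shown here alone, is how plain phenyl, or a smaller group such as an amine or a methyl, would behave at this position.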